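From ethyl to octyl: does chain length restore inhibition?

A few compounds are considered here, and "the series" means these few. Any claim that something is new, unique, unknown or untested is made for them only; others in the source may bear on it.

Values from a functional assay on cells (T-cell line, Homo sapiens) for inhibition (on this read-out lower numbers stand for stronger inhibition and higher numbers for weaker inhibition), follow
compound 1 `COc1ccc(CCCN2CCC(COCc3ccc(Cl)cc3)CC2)cc1` gives 500 nM
compound 2 `Clc1ccccc1CCCN1CCC(COC(c2ccccc2)c2ccccc2)CC1` gives 800 nM
compound 3 `CCN1CCC(COC(c2ccccc2)c2ccccc2)CC1` gives > 20000 nM

Compound 3 has no exact number, because its reading of > 20000 nM is a limit of the assay. Compound 4 `CCCCCCCCN1CCC(COC(c2ccccc2)c2ccccc2)CC1` carries hexyl in place of hydrogen on a saturated chain carbon, two bonds along the chain from an amine nitrogen in a ring. For the measured compounds named here, one measured step bears on this place. Putting hydrogen in place of 2-chlorobenzyl there gave an at least 25-fold higher number from compound 2 to compound 3 (1.39 log units; beyond the scatter), a large change. Hexyl restores bulk at that place, so a large move toward lower numbers in this assay is expected, resting on that step alone. The estimated change is an at least 10-fold lower number from compound 3 to compound 4 (1.00 log units; beyond the scatter). Compound 4 is expected to give about 2000 nM, within an estimated range of 500 nM to 8000 nM.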

Compound 4, half-maximal inhibitory concentration: 700 nM
Beside the measured number, compound 4's estimate is 2.9-fold (0.46 log units) above it; the range from low to high includes it.
By their numbers in this assay, from the lowest: compounds 1, 4 and 2 (each within the scatter of the next). At a limit, above all of these: compound 3.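

In this assay, lengthening ethyl to octyl brings inhibition back, a large step: an at least 28-fold lower number from compound 3 to compound 4 (1.45 log units; beyond the scatter). Going by these compounds, compound 3 stands at a limit, so the true size of this step stays unknown: the limit of > 20000 nM in this assay, at which 1 of the 4 values shown sits. Hexyl, with no ring, also serves as well as 2-chlorophenyl at this place, and the step of a 1.1-fold lower number from compound 2 to compound 4 (0.06 log units; within the scatter) shows that an aromatic ring on the chain is not needed to reach this level of inhibition. Where between ethyl and octyl inhibition returns stays open, as does what a butyl chain, a longer chain or a carboxylic acid on the chain would give.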